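Compound 2 and its double-bond partner

The source may report more compounds than this note shows. Statements on the series, on what has been measured and on what is new or still open speak of the compounds shown alone.

Within the data shown here, in a functional assay on MCF7 cells (Homo sapiens) for antiproliferative activity, read by sulforhodamine B assay, with a stated time of 72 h (a higher number here means a weaker inhibitor, a lower number a stronger inhibitor), compound 1 (`COc1ccc2nc(Cl)c(/C=C\c3ccc(C(F)(F)F)cc3)cc2c1`) gives 12400 nM as the higher of the two numbers so far. Compound 2 (`FC(F)(F)c1cccc(/C=C\c2cc3ccccc3nc2Cl)c1`) gives 3530 nM as the lower of the two, and its gap to compound 1 lies beyond the usual scatter. These two compounds differ in more than one place, so that gap says nothing about configuration on its own.

The change to compound 3 (`FC(F)(F)c1cccc(/C=C/c2cc3ccccc3nc2Cl)c1`) is one of configuration only (the two compounds have the same atoms and bonds and differ only in configuration as drawn: 1 of 1 stereo elements differ; a double bond is drawn Z in compound 2 and E in compound 3) and a double bond is drawn Z in compound 2 and E in compound 3. Among the measured compounds shown here, both measured compounds are drawn Z, so no measured pair shows the size of this step in this assay and the expectation rests on judgement alone. From the compounds shown here alone, a move to a higher number is expected, probably beyond the scatter, though a step within it remains open. The estimated 2.3-fold higher number from compound 2 to compound 3 (0.36 log units; beyond the scatter) points toward weaker inhibition. For compound 3 the expected value is 8000 nM with an estimated range from 2000 nM to 30000 nM in four of five measurements.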

Compound 3, half-maximal inhibitory concentration: 24400 nM
Beside the measured number, compound 3's estimate is 3.1-fold (0.48 log units) below it; low and high end bracket the measured number.
By their numbers in this assay, from the lowest: compound 2; then compounds 1 and 3 (each within the scatter of the next).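

In this assay, turning the double bond from Z to E gives a 6.9-fold higher number from compound 2 to compound 3 (0.84 log units; beyond the scatter), so for this pair the Z form is the stronger inhibitor of cell growth. This step can be assigned to the double bond alone because nothing else changes between the two structures: the fact that compounds 2 and 3 differ only in the configuration as drawn. Compounds 1 and 2 differ in more than one place and could not separate configuration from other changes, whereas this pair shows that configuration alone moves the number beyond the scatter, though only for one pair with the trifluoromethyl group and the chlorine held constant.

The compounds shown leave open whether the step keeps its direction and size when the trifluoromethyl group gives way to a nitrile or an amine, or when a carboxylic acid is placed on the same ring. They also do not show how a saturated two-carbon chain in place of the double bond would compare with either configuration, or why the Z form gives the lower number.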